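A few compounds are considered here, and "the series" means these few. Any claim that something is new, unique, unknown or untested is made for them only; others in the source may bear on it.

Compound 1 `CC1=CC[C@H](C(C)C)c2cc(C)c(OC(=O)c3ccc([N+](=O)[O-])cc3)cc21` is an ester in which a nitro-bearing benzoyl group is attached, through an oxygen, to an aromatic core that carries an isopropyl group and a methyl group. For the measured compounds named here, in a functional assay on MCF7 cells (Homo sapiens) for antiproliferative activity, read by sulforhodamine B assay, with a stated time of 48 h, tested at 50 uM (a lower number here means less inhibition, a higher number more inhibition at the concentration tested (going by the name of the read-out)), compound 1 gives 72.9%, the higher of the two numbers measured so far. The other measured compound, compound 2 `Cc1cc2c(C(C)C)ccc(C)c2cc1OC(=O)c1ccc(C(F)(F)F)cc1`, carries a trifluoromethyl group on its benzoyl ring instead of a nitro group and sits on a different core; in this assay compound 2 gives 16.8%, a gap beyond the usual scatter.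

Compound 3 `CC1=CC[C@H](C(C)C)c2cc(C)c(OC(=O)c3cccc([N+](=O)[O-])c3)cc21` has not yet been measured. It keeps the core and the ester of compound 1, and differs only in the benzoyl ring: 3-nitrophenyl in place of 4-nitrophenyl on a carbonyl carbon. The atoms are the same; only the position of the nitro group on that ring has moved. Going by the values given here, no measured pair shows this change, so the size of the step is uncertain. A moderate downward step, or none beyond the scatter, is expected, giving a number 10.9 percentage points lower from compound 1 to compound 3 (beyond the scatter). Compound 3 is estimated at 62%, within 35% to 85%.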

Compound 3, a percentage reported as inhibition, at one concentration (the size of the read-out at that concentration, not a potency): 29.3%
Compound 3: middle estimate off by 32.7 percentage points, on the high side; measured number below the stated range.
By their numbers in this assay, from the lowest: compound 2; then compound 3; then compound 1.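

On the core and ester shared by both compounds, 3-nitrophenyl in place of 4-nitrophenyl on a carbonyl carbon leaves the atoms unchanged, yet in this assay it gives a number 43.6 percentage points lower from compound 1 to compound 3 (beyond the scatter). For the compounds shown here, this is the first pair here that differs in one place, and it shows that the read-out at this concentration depends on where the nitro group sits on the ring, so having a nitro group on this ring does not alone secure the higher number. Nothing available here explains why moving the group has so large an effect.

On these data alone, what remains open is whether 4-nitrophenyl is a special case, or whether an amine or a carboxylic acid on that ring would keep or lose the inhibition seen with compound 1. The trifluoromethyl group also remains unresolved: it appears only in compound 2, which has a different core, so its effect cannot be separated from that of the core, and a reading at one concentration does not give a potency for any of these compounds.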